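The source may report more compounds than this note shows. Statements on the series, on what has been measured and on what is new or still open speak of the compounds shown alone.

Series notes, metabolic stability. In an ADME assay on microsomes from liver (Homo sapiens) for metabolic stability, read by LC-MS, with a stated time of 10 min (on this read-out lower numbers stand for a less stable compound and higher numbers for a more stable compound), compound 1 `C[C@@H]1CN(c2cccc3c2C[C@H](CN(C)[C@H]2CCCc4cccnc42)NC3)C[C@H](C)N1` gives 100% and compound 2 `CN(C[C@H]1Cc2c(cccc2N2CCNCC2)CN1)[C@H]1CCCc2cccnc21` gives 99.7%; the step of a number 0.3 percentage points lower from compound 1 to compound 2 (within the scatter) shows that the two values sit together. Compound 3 `C[C@@H]1CN(c2cccc3c2C[C@H](CN(C)[C@H]2CCCc4cccnc42)NC3)C[C@H](C)N1C` gives 24.6% in this assay, the lowest of the three numbers, with compound 2 nearest and compound 1 furthest, both beyond the scatter. The steps into compound 3 are both large: a number 75.4 percentage points lower from compound 1 to compound 3 (beyond the scatter) and a number 75.1 percentage points lower from compound 2 to compound 3 (beyond the scatter).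

Compound 4 `CN(C[C@H]1Cc2c(cccc2N2CCNC(C)(C)C2)CN1)[C@H]1CCCc2cccnc21` carries 3,3-dimethylpiperazin-1-yl in place of 3,4,5-trimethylpiperazin-1-yl on an aromatic carbon. The change restores a hydrogen-bond donor on the ring, as counted. Within the data shown here, the steps that bear on it are the two large drops into compound 3, and the step of a number 0.3 percentage points lower from compound 1 to compound 2 (within the scatter), which shows that methyl groups on the ring carbons of the piperazine leave the read-out unchanged within the scatter. Compound 4 is therefore expected to give a large step upward, a number 68.4 percentage points higher from compound 3 to compound 4 (beyond the scatter), back toward the level of compound 1 and compound 2. The estimate for compound 4 in this assay is 93%, with a range of 75% to 100%.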

Compound 4, percent of the compound remaining: 100%
The estimate for compound 4 lay 7 percentage points below the measured number; low and high end bracket the measured number.
By their numbers in this assay, from the lowest: compound 3; then compounds 2, 1 and 4 (each within the scatter of the next).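

Placing 3,3-dimethylpiperazin-1-yl in place of 3,4,5-trimethylpiperazin-1-yl on this aromatic carbon gives a number 75.4 percentage points higher from compound 3 to compound 4 (beyond the scatter) in this assay, so a piperazine with methyl groups on a ring carbon and a hydrogen on the ring amine nitrogen does not share the low number of compound 3. The placement of those carbon methyl groups makes no difference beyond the scatter at this position, with no change at the digits printed from compound 1 to compound 4 (within the scatter) and a number 0.3 percentage points higher from compound 2 to compound 4 (within the scatter) placing the gem-dimethyl ring with the 3,5-dimethyl and unsubstituted rings. No supporting data bear on the reason for these steps.

The compounds shown leave open how an ethyl or acetyl group on that ring nitrogen would read in this assay. Also open, on these data alone, is whether a morpholine at this aromatic carbon would sit with compound 4 or with compound 3.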